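Swapping the aryl group on the shared core: compound 4

This account rests on a few compounds, and the source may have more. Where it says the series, first, only, none or still open, it means among the compounds named here.

Compounds measured so far:
- compound 1 `CCNC(=O)c1cc(Oc2ccc(NC(=O)c3cc4cccnc4n(-c4ccc(C(F)(F)F)cc4Cl)c3=O)cc2)ccn1`: 3290 nM
- compound 2 `CCCNC(=O)c1cc(Oc2ccc(NC(=O)c3cc4cccnc4n(-c4ccc(Cl)cc4)c3=O)cc2)ccn1`: 120 nM
- compound 3 `CCCNC(=O)c1cc(Oc2ccc(NC(=O)c3cc4cccnc4n(-c4ccc(Br)cc4F)c3=O)cc2)ccn1`: 1310 nM

In a functional assay on A549 cells (Homo sapiens) for antiproliferative activity, read by MTT assay, with a stated time of 72 h (a lower number here means a stronger inhibitor, a higher number a weaker inhibitor), compound 3 gives 1310 nM, the second highest of the three numbers; compound 2 gives the lower number 120 nM and compound 1 the higher number 3290 nM, both gaps beyond the scatter. The step to compound 4 `CCCNC(=O)c1cc(Oc2ccc(NC(=O)c3cc4cccnc4n(-c4ccc(C(F)(F)F)cc4Cl)c3=O)cc2)ccn1` is 2-chloro-4-(trifluoromethyl)phenyl in place of 4-bromo-2-fluorophenyl on an aromatic nitrogen. Going by the values given here, the one measured step at this position, an 11-fold higher number from compound 2 to compound 3 (1.04 log units; beyond the scatter), shows that the aryl group on the aromatic nitrogen can shift the number by a large amount. Among the compounds with values here, no step with the entering group is available; compound 1, which carries the same 2-chloro-4-(trifluoromethyl)phenyl but an ethyl amide instead of propyl, gives 3290 nM, the highest number seen. Compound 4 is therefore expected to land near compound 1, with a 1.9-fold higher number from compound 3 to compound 4 (0.28 log units; within the scatter) as the estimated step from compound 3, which is a modest rise. The estimate for compound 4 is 2500 nM, within 800 nM to 8000 nM.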

Compound 4, half-maximal inhibitory concentration: 1250 nM
The estimate for compound 4 lay 2.0-fold (0.30 log units) above the measured number; low and high end bracket the measured number.
By their numbers in this assay, from the lowest: compound 2; then compounds 4 and 3 (each within the scatter of the next); then compound 1.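

In this assay the step is small: a 1.0-fold lower number from compound 3 to compound 4 (0.02 log units; within the scatter) shows that 2-chloro-4-(trifluoromethyl)phenyl and 4-bromo-2-fluorophenyl cannot be told apart, despite their different halogens and sizes. Among the propyl amides, 4-chlorophenyl alone goes with the low number, since a 10-fold higher number from compound 2 to compound 4 (1.02 log units; beyond the scatter) stands alongside an 11-fold higher number from compound 2 to compound 3 (1.04 log units; beyond the scatter) as a second large rise. The chain on the amide also counts, as a 2.6-fold lower number from compound 1 to compound 4 (0.42 log units; beyond the scatter) shows when ethyl is lengthened to propyl with the aryl group held fixed. Plain phenyl and a butyl amide would test whether these two trends hold beyond the groups shown. What lies behind these steps remains open, as no measurement here speaks to a cause.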